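Furan-2-yl for 4-nitrophenyl on the saturated ring carbon

The compounds below may be only part of what the source reports. "The series", "measured", "known", "first", "only" and "open" are said of these compounds alone.

In an assay for inhibition of Thromboxane-A synthase (Homo sapiens), using microsomes (a higher number here means a weaker inhibitor, a lower number a stronger inhibitor), compound 2 `O=C(O)CC/C=C\CC1COC(c2ccc([N+](=O)[O-])cc2)OC1c1cccnc1` gives 39 nM, and compound 1 `O=C(O)CC/C=C\CC1COC(c2ccccc2Cl)OC1c1cccnc1` gives 48 nM; the step of a 1.2-fold lower number from compound 1 to compound 2 (0.09 log units; within the scatter) stays within the scatter, so the two numbers cannot be ranked. Compound 3 `O=C(O)CC/C=C\CC1COC(c2ccco2)OC1c1cccnc1` carries furan-2-yl in place of 4-nitrophenyl on a saturated ring carbon. Among the compounds with values here, the only step that bears on this is the exchange of one aryl group for another at the same carbon, a 1.2-fold lower number from compound 1 to compound 2 (0.09 log units; within the scatter), which left this assay essentially unchanged. A similar exchange here is therefore expected to give no step beyond the scatter, a 1.2-fold higher number from compound 2 to compound 3 (0.06 log units; within the scatter). Compound 3 is estimated at 45 nM in this assay, with a range of 20 nM to 110 nM.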

Compound 3, half-maximal inhibitory concentration: 164 nM
For compound 3 the middle estimate is 3.6-fold (0.56 log units) below the measured one; measured number outside the range, above it.
By their numbers in this assay, from the lowest: compounds 2 and 1 (each within the scatter of the next); then compound 3.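

In this assay, the group on the saturated ring carbon between two ring oxygen atoms is not freely exchangeable: furan-2-yl gives a 4.2-fold higher number from compound 2 to compound 3 (0.62 log units; beyond the scatter) and a 3.4-fold higher number from compound 1 to compound 3 (0.53 log units; beyond the scatter) while compound 1 and compound 2 cannot be ranked against each other. This position therefore responds to the aromatic group it carries, though the steps are modest. Nothing measured here accounts for these steps.

Still open, from the compounds shown here alone, is whether the five-membered ring or the loss of the phenyl substituent goes with the higher number. Unsubstituted phenyl and thiophen-2-yl at this carbon would separate the two.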